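A few compounds are considered here, and "the series" means these few. Any claim that something is new, unique, unknown or untested is made for them only; others in the source may bear on it.

Measured so far in an ADME assay on Vero cells (Chlorocebus sabaeus) for cytotoxicity, read by CellTiter-Glo, with a stated time of 72 h; a lower number here means that less compound is tolerated, a higher number that more compound is tolerated:
Compound 1 `[O-][n+]1nc(N[C@@H]2C[C@H]3CC[C@@H]2C3)[n+]([O-])c2ccc(F)cc21`: < 2.5 ug/mL
Compound 2 `COc1ccc2c(c1)[n+]([O-])nc(NC1CCC1)[n+]2[O-]`: 9.8 ug/mL

A cytotoxicity test like this one shows how much compound cells can take before they begin to die. Among the measured compounds shown here, compound 2 gives 9.8 ug/mL, the only true number available so far. Compound 1 gives < 2.5 ug/mL, which is a limit of the assay and not a number.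

Compound 3 `COc1ccc2c(c1)[n+]([O-])nc(N[C@@H]1C[C@H]3CC[C@@H]1C3)[n+]2[O-]` keeps the core of compound 2 and differs in one place, on a nitrogen on an aromatic ring. The change is a group of 7 heavy atoms (7 carbon; 2 five-membered non-aromatic rings of carbon only) in place of a group of 4 heavy atoms (4 carbon; one four-membered non-aromatic ring of carbon only), on a nitrogen on an aromatic ring. For the measured compounds named here, no measured pair isolates this swap, so any forecast is loose.

Going by the values given here, the one clue is that compound 1 carries the same entering group, and in this assay compound 1 reads < 2.5 ug/mL. On that single limit, less tolerance is expected rather than more. The expected change is a 2.8-fold lower number from compound 2 to compound 3 (0.45 log units; beyond the scatter), a moderate drop. The estimated value for compound 3 is 3.5 ug/mL, with an expected range of 1.5 ug/mL to 8 ug/mL.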

Compound 3, half-maximal cytotoxic concentration: > 50 ug/mL
Compound 3 was reported as a limit; the forecaster's own chance of this, stated with the estimate: 35%; middle value at least 14-fold (1.15 log units) away from the limit.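

In this assay, the step of an at least 5.1-fold higher number from compound 2 to compound 3 (0.70 log units; beyond the scatter) shows that, with methoxy on the core, cells tolerate more compound when the group on this nitrogen has 2 five-membered non-aromatic rings of carbon only than when it is cyclobutyl. From the compounds shown here alone, compound 3 gives > 50 ug/mL, which is a limit of the assay and not a number, so the true size of this rise remains unknown. Compound 1 carries the same group on the nitrogen, yet methoxy in place of fluoro on an aromatic carbon gives an at least 20-fold higher number from compound 1 to compound 3 (1.30 log units; beyond the scatter), so this group does not by itself bring the low tolerance seen for compound 1, and the substituent on the aromatic carbon also matters.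

The compounds shown do not tell how cyclobutyl would read with fluoro on the aromatic carbon, so it remains unclear whether the two changes act independently or only in combination. They also leave open whether a longer chain such as n-butyl on the nitrogen, or chloro on the aromatic carbon, would follow compound 3 or compound 1 in this measure.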